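Adding a hydroxy group to compound 2

The compounds below may be only part of what the source reports. "The series", "measured", "known", "first", "only" and "open" are said of these compounds alone.

- compound 1 `N=C(N)c1ccc(-c2cc3cc(C(=N)N)ccc3o2)cc1` gives 1900 nM
- compound 2 `c1cc(-c2cc3ccc(C4=NCCN4)cc3o2)ccc1C1=NCCN1` gives 4500 nM

In an ADME assay on L6 cells (Rattus norvegicus) for cytotoxicity (on this read-out higher numbers stand for weaker inhibition and lower numbers for stronger inhibition), only these two compounds have been measured. Compound 2 stands highest of the two at 4500 nM. Compound 1 gives 1900 nM, and the gap between the two compounds lies beyond the scatter. Compound 3 `Oc1cc(C2=NCCN2)ccc1-c1cc2ccc(C3=NCCN3)cc2o1` has not yet been measured. It differs from compound 2 by hydroxy in place of hydrogen on an aromatic carbon, ortho to a large group and meta to a group of 5 heavy atoms (hydroxy in place of hydrogen on an aromatic carbon). Among the measured compounds shown here, no pair of measured compounds differs in one place only, so the data give no direct guide to the size of this change. No shift beyond the scatter is therefore expected, and the estimated step is a 1.2-fold higher number from compound 2 to compound 3 (0.09 log units; within the scatter). For compound 3 the expected value is 5500 nM, with an estimated range from 1800 nM to 20000 nM.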

Compound 3, half-maximal inhibitory concentration: > 193000 nM
Compound 3 ended at the assay's limit; the forecaster's own chance of this, stated with the estimate: 10%; at least 35-fold (1.54 log units) between middle value and limit.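

In this assay, compound 3 gives > 193000 nM, which is a limit of the assay and not a number. Hydroxy in place of hydrogen on this aromatic carbon, ortho to a large group and meta to a group of 5 heavy atoms, brings an at least 42-fold higher number from compound 2 to compound 3 (1.63 log units; beyond the scatter), the first single-place step seen here, and it moves towards weaker inhibition of the cells. From the compounds shown here alone, the true size of this step stays unknown because the value rests at the end of the range: the limit of > 193000 nM in this assay, at which 1 of the 3 values shown sits.

The compounds shown leave open whether this shift belongs to the hydroxy group itself or would also come with a methoxy group or a fluorine atom on the same carbon. They also leave open whether the same change would act alike on compound 1.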